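The source may hold more compounds than are shown below. What is called first, only, known or untested is meant among the compounds shown, and "the series" means these compounds.

Measured so far:
compound 1 `COc1cccc(-c2c(C)n(Cc3c(F)cccc3F)c(=O)n(C[C@H](NC(C)C)C3CCCC3)c2=O)c1F` gives 12 nM in an assay on HEK293 cells for binding affinity to Gonadotropin-releasing hormone receptor (Homo sapiens), read by radioligand binding; on this read-out higher numbers stand for weaker inhibition and lower numbers for stronger inhibition.
compound 2 `COc1cccc(-c2c(C)n(Cc3c(F)cccc3F)c(=O)n(C[C@@H](C3CCCCC3)N(C)C)c2=O)c1F` gives 4.1 nM in this assay.

Among the compounds with values here, compound 2 holds the lowest of the two numbers; the only step leading to it, a 2.9-fold lower number from compound 1 to compound 2 (0.47 log units; beyond the scatter), altered ring size and amine substitution together. Compound 3 `COc1cccc(-c2c(C)n(Cc3c(F)cccc3F)c(=O)n(C[C@H](N)C3CCCC3)c2=O)c1F` carries amino(cyclopentyl)methyl in place of cyclohexyl(dimethylamino)methyl on a saturated chain carbon bound to an aromatic nitrogen; the five-membered ring returns as in compound 1, while the nitrogen now bears no alkyl group at all. Within the data shown here, only that one step bears on this change, and it ran in the opposite direction, so a partial reversal seems likely. A modest rise in this assay is expected for compound 3, a 2.4-fold higher number from compound 2 to compound 3 (0.39 log units; beyond the scatter). Compound 3 is estimated at 10 nM, range 4 nM to 30 nM.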

Compound 3, inhibition constant: 10 nM
For compound 3 middle estimate and measured number coincide at the digits printed; the measured number falls inside the stated range.
By their numbers in this assay, from the lowest: compound 2; then compounds 3 and 1 (each within the scatter of the next).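

In this assay, within the data shown here, hydrogen in place of isopropyl on an amine nitrogen gives a 1.2-fold lower number from compound 1 to compound 3 (0.08 log units; within the scatter), the first reading of the amine substituent alone: with the cyclopentyl ring kept, the isopropyl group and the free amine cannot be told apart. The other step, a 2.4-fold higher number from compound 2 to compound 3 (0.39 log units; beyond the scatter), remains a joint change of ring size and amine substitution and cannot be split between the two. No measurement on hand accounts for these numbers. As far as these compounds go, whether the cyclohexyl ring or the dimethylamino group goes with the lower number of compound 2 stays open. Cyclopentyl(dimethylamino)methyl or amino(cyclohexyl)methyl at this place would separate them, and a cycloheptyl ring would extend the ring-size question.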